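From methoxy to ethoxy: compound 3 to compound 4

This account rests on a few compounds, and the source may have more. Where it says the series, first, only, none or still open, it means among the compounds named here.

Series on one shared core: compound 1 `CNc1nc(-c2cc(OC)c(OC)c(OC)c2)c(-c2ccc(C)cc2)s1`, compound 2 `CNc1nc(-c2cc(OC)c(OC)c(OC)c2)c(-c2ccc(C(F)(F)F)cc2)s1` and compound 3 `CNc1nc(-c2cc(OC)c(OC)c(OC)c2)c(-c2ccc(OC)cc2)s1`. In a functional assay on Jurkat cells (Homo sapiens) for antiproliferative activity, read by MTT assay, with a stated time of 72 h (a higher number here means a weaker inhibitor, a lower number a stronger inhibitor), compound 1 gives 19 nM, compound 2 gives 3010 nM and compound 3 gives 34.3 nM. Compound 3 therefore stands level with compound 1 and far from compound 2.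

Next is compound 4 `CCOc1ccc(-c2sc(NC)nc2-c2cc(OC)c(OC)c(OC)c2)cc1`, which turns 4-methoxyphenyl into 4-ethoxyphenyl: methyl in place of hydrogen on a saturated chain carbon bound to an oxygen on an aromatic ring. Among the compounds with values here, no measured step extends this chain, so the evidence is indirect. Two steps are large, a 160-fold higher number from compound 1 to compound 2 (2.20 log units; beyond the scatter) and an 88-fold lower number from compound 2 to compound 3 (1.94 log units; beyond the scatter), and both involve trifluoromethyl, which compound 4 does not carry. The closer precedent is the exchange of methyl for methoxy, a 1.8-fold higher number from compound 1 to compound 3 (0.26 log units; within the scatter), which stays small. In this assay, from the compounds shown here alone, a small step towards a higher number is therefore expected, possibly not beyond the scatter, though a single added methyl remains untested here. The estimated step is a 1.6-fold higher number from compound 3 to compound 4 (0.21 log units; within the scatter). For compound 4 the expected value is 55 nM, within an estimated range of 15 nM to 200 nM.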

Compound 4, half-maximal inhibitory concentration: 1.7 nM
Compound 4: middle estimate off by 32-fold (1.51 log units), on the high side; the measured number lies below the stated range.
By their numbers in this assay, from the lowest: compound 4; then compounds 1 and 3 (each within the scatter of the next); then compound 2.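

In this assay the exchange of methyl for methoxy moved little, with a 1.8-fold higher number from compound 1 to compound 3 (0.26 log units; within the scatter) and no clear reading of this position, whereas the single added methyl of methoxy to ethoxy gives a 20-fold lower number from compound 3 to compound 4 (1.30 log units; beyond the scatter) and shows that a saturated chain carbon bound to an oxygen on an aromatic ring is far from indifferent. Ethoxy also separates from the other groups on the aromatic carbon, with an 11-fold lower number from compound 1 to compound 4 (1.05 log units; beyond the scatter) and with a 1800-fold lower number from compound 2 to compound 4 (3.25 log units; beyond the scatter) in the same series, which leaves compound 4 with the lowest number of the four. Nothing shown here accounts for the size of these steps.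

Open, from the compounds shown here alone, is whether the low number holds or falls with a longer chain such as propoxy or butoxy, or a branched one such as isopropoxy. Also open, going by these compounds, is whether the oxygen matters, a question that an ethyl group in place of ethoxy would address.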